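From 4-chlorophenyl to 3-hydroxyphenyl at an assay limit

The source may hold more compounds than are shown below. What is called first, only, known or untested is meant among the compounds shown, and "the series" means these compounds.

In an ADME assay on L929 cells (Mus musculus) for cytotoxicity, read by resazurin assay, with a stated time of 72 h (a higher number here means a weaker inhibitor, a lower number a stronger inhibitor), compound 1 `O=C(/C=C/c1ccc2c(c1)B(O)OC2)c1ccccc1F` gives > 10 ug/mL, which is a limit of the assay and not a number. Compound 2 `O=C(/C=C/c1ccc2c(c1)B(O)OC2)c1ccc(Cl)cc1` gives > 10 ug/mL, which is also a limit. Compound 2 therefore has no exact value and stands with compound 1 at the limit of > 10 ug/mL in this assay, at which 2 of the 2 values shown sit.

The next structure, compound 3 `O=C(/C=C/c1ccc2c(c1)B(O)OC2)c1cccc(O)c1`, makes one change to compound 2: 3-hydroxyphenyl in place of 4-chlorophenyl on a carbonyl carbon. For the measured compounds named here, the one measured step that bears on this change also altered the group on the carbonyl carbon: a step that the two limits leave unreadable from compound 1 to compound 2. That step has no readable size, so no direction can be expected in this assay, and the expectation stays near the same limit.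

For compound 3 the estimated value is 15 ug/mL, with an expected range from 6 ug/mL to 40 ug/mL. This estimate means an expected step that the limit leaves unreadable from compound 2 to compound 3.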

Compound 3, half-maximal inhibitory concentration: 7.56 ug/mL
For compound 3 the middle estimate is 2.0-fold (0.30 log units) above the measured one; the range from low to high includes it.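

Placing 3-hydroxyphenyl on the carbonyl carbon yields the first exact number among these compounds: in this assay compound 3 gives 7.56 ug/mL. This change gives an at least 1.3-fold lower number from compound 2 to compound 3 (0.12 log units; that floor lies within the scatter), and the replacement of 2-fluorophenyl gives an at least 1.3-fold lower number from compound 1 to compound 3 (0.12 log units; that floor lies within the scatter); each figure is only a floor, so the data do not establish a real difference, although the true size could be larger. The other two compounds stay at an assay limit, which is why neither step has a known full size: the limit of > 10 ug/mL in this assay, at which 2 of the 3 values shown sit.

From the compounds shown here alone, how far either step extends remains open, since only compound 3 has an exact number. Also open, going by these compounds, is how an amine or a carboxylic acid on the phenyl ring would read in this assay in place of the hydroxyl group.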